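The source may hold more compounds than are shown below. What is called first, only, known or untested is meant among the compounds shown, and "the series" means these compounds.

Measured so far:
- compound 1, `CC(C)(C)NC(=O)NCCS(=O)(=O)NC(=O)c1ccc(Nc2nc(NC3(c4ccc(Cl)cc4)CC3)nc(OCC(F)(F)F)n2)cc1`, 93% in an ADME assay on microsomes from liver (Rattus norvegicus) for metabolic stability, with a stated time of 10 min; on this read-out higher numbers stand for a more stable compound and lower numbers for a less stable compound
- compound 2, `CCS(=O)(=O)NC(=O)c1ccc(Nc2nc(NC3(c4ccc(Cl)cc4)CC3)nc(OCC(F)(F)F)n2)cc1`, 85% in this assay

Within the data shown here, compound 2 stands at the lower of the two numbers, with compound 1 as its only neighbour; the step of a number 8 percentage points lower from compound 1 to compound 2 (within the scatter) lies within the scatter, so the two compounds cannot be told apart on this read-out.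

Compound 3, `O=C(NS(=O)(=O)c1ccccc1)c1ccc(Nc2nc(NC3(c4ccc(Cl)cc4)CC3)nc(OCC(F)(F)F)n2)cc1`, has not yet been measured. It differs from compound 2 in one place: phenyl in place of ethyl on a sulfonyl sulfur. Among the measured compounds shown here, the only measured step, from compound 1 to compound 2, touched the chain on the sulfonyl sulfur and gave a change within the scatter; no measured pair exchanges an alkyl for an aryl group on that sulfur, so nothing bears directly on the change to compound 3.

Given that the one step known, a number 8 percentage points lower from compound 1 to compound 2 (within the scatter), stayed within the scatter, compound 3 is expected to remain in the same region, with a step of a number 5 percentage points lower from compound 2 to compound 3 (within the scatter). Compound 3 is estimated at 80% in this assay, within a range from 60% to 95%.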

Compound 3, percent of the compound remaining: 100%
For compound 3 the middle estimate is 20 percentage points below the measured one; measured number outside the range, above it.
By their numbers in this assay, from the lowest: compounds 2, 1 and 3 (each within the scatter of the next, the first and the last beyond it).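

On the sulfonyl sulfur, the exchange of ethyl for phenyl gives the one step among these compounds that lies beyond the scatter in this assay: a number 15 percentage points higher from compound 2 to compound 3 (beyond the scatter), a modest change that shows this position can move the read-out. The same position also carries phenyl in place of 2-(((tert-butyl)carbamoyl)amino)ethyl, with a number 7 percentage points higher from compound 1 to compound 3 (within the scatter) and within the scatter, so the aromatic ring and the long substituted chain cannot be told apart here, and only the ethyl and phenyl groups separate. Nothing available explains why phenyl and ethyl differ on this read-out.

The three compounds leave open whether the separation belongs to the aromatic ring itself or would also appear with a longer alkyl group on the sulfur, such as butyl, or with a benzyl group, whose ring stands one carbon further out. They also leave open whether a phenyl ring carrying a methoxy group or a chlorine, or a pyridine ring in its place, would stay level with compound 3 or fall back towards compound 2.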